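This account rests on a few compounds, and the source may have more. Where it says the series, first, only, none or still open, it means among the compounds named here.

Measured so far in a physicochemical assay for solubility, using the shake flask method, measured as kinetic solubility, with a stated time of 20 h, at pH 2; on this read-out lower numbers stand for lower solubility and higher numbers for higher solubility:
- compound 1 `FC(F)(F)c1cccc(-c2nc3cnc(Nc4ccccn4)cc3[nH]2)c1`: 21000 nM
- compound 2 `COc1cccnc1Nc1cc2[nH]c(-c3cccc(C(F)(F)F)c3)nc2cn1`: 116000 nM
- compound 3 `COc1ccc(Nc2cc3[nH]c(-c4cccc(C(F)(F)F)c4)nc3cn2)nc1`: < 5000 nM (a limit)

Compound 3 has only a limit in this assay, and no number: the limit of < 5000 nM in this assay, at which 1 of the 3 values shown sits.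

The next structure is compound 4 `FC(F)(F)c1cccc(-c2nc3cnc(Nc4ccncn4)cc3[nH]2)c1`, with pyrimidin-4-yl in place of 5-methoxypyridin-2-yl on a nitrogen on an aromatic ring. Among the compounds with values here, no measured step makes this exact change, so the evidence is indirect. Compound 4 has no methoxy, and the closest measured compound without one is compound 1 at 21000 nM. The relevant step is an at least 4.2-fold lower number from compound 1 to compound 3 (0.62 log units; beyond the scatter), which suggests that losing the methoxy of compound 3 should raise the number. The methoxy step a 5.5-fold higher number from compound 1 to compound 2 (0.74 log units; beyond the scatter) runs the other way, and an at least 23-fold lower number from compound 2 to compound 3 (1.36 log units; beyond the scatter) is large, so the methoxy steps give no single direction and the range must stay wide.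

The expected step is a higher number, modest or larger: an at least 4.0-fold higher number from compound 3 to compound 4 (0.60 log units; beyond the scatter). For compound 4 the estimated value is 20000 nM, with an expected range of 6000 nM to 70000 nM.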

Compound 4, solubility: 200000 nM
Compound 4: middle estimate off by 10-fold (1.00 log units), on the low side, and the stated range ends below it.
By their numbers in this assay, from the lowest: compound 1; then compounds 2 and 4 (each within the scatter of the next). At a limit, below all of these: compound 3.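

In this assay, pyrimidin-4-yl in place of pyridin-2-yl on the same nitrogen gives a 9.5-fold higher number from compound 1 to compound 4 (0.98 log units; beyond the scatter), so a high number at this position does not depend on a methoxy. The comparison with the 3-methoxypyridin-2-yl group gives a 1.7-fold higher number from compound 2 to compound 4 (0.24 log units; within the scatter), which allows no order between those two groups. The remaining step, an at least 40-fold higher number from compound 3 to compound 4 (1.60 log units; beyond the scatter), rests on a limit and not on a number: the limit of < 5000 nM in this assay, at which 1 of the 4 values shown sits.

On these data alone, it stays open how far the number for the 5-methoxypyridin-2-yl group really lies under that limit, and so how large this step is. Also open, as far as these compounds go, is whether a pyrimidin-4-yl ring carrying a methoxy or a dimethylamino group would keep the number of the unsubstituted pyrimidin-4-yl group.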